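A few compounds are considered here, and "the series" means these few. Any claim that something is new, unique, unknown or untested is made for them only; others in the source may bear on it.

Of the compounds shown here, three sharing one core have been tested in a functional assay on MGC-803 cells (Homo sapiens) for inhibition, read by MTT assay, with a stated time of 72 h; a higher number here means a weaker inhibitor, a lower number a stronger inhibitor. Compound 1 `CC(C)n1ncc2c(C(=O)NC3CCCC3)cccc21` carries a cyclopentyl amide on that core. In this assay compound 1 reaches only the limit of the test, > 40000 nM. Compound 2 `Cc1ccc(-n2cc(CNC(=O)c3cccc4c3cnn4C(C)C)nn2)cc1C` carries instead a 3,4-dimethylphenyl on an aromatic nitrogen. In this assay compound 2 likewise gives only a limit, > 40000 nM. Compound 3 `Cc1ccccc1-n1cc(CNC(=O)c2cccc3c2cnn3C(C)C)nn1` carries a 2-methylphenyl in place of that group. In this assay compound 3 stands at a limit as well, > 40000 nM. The step that the two limits leave unreadable from compound 2 to compound 3 is therefore not readable. Going by the values given here, all three values sit at the limit of > 40000 nM in this assay, at which 3 of the 3 values shown sit, so compound 3 stands nowhere measurable among the numbers so far. Compound 4 `COc1ccc(Cn2cc(CNC(=O)c3cccc4c3cnn4C(C)C)nn2)cc1` differs from compound 3 in one place: 4-methoxybenzyl in place of 2-methylphenyl on an aromatic nitrogen. Among the compounds with values here, no measured step bears on this change, since the only neighbouring step is unreadable. The estimated step is therefore a number no higher from compound 3 to compound 4 (the limit leaves the size open), no change beyond the scatter. Compound 4 is estimated at 40000 nM in this assay, with a range from 15000 nM to 100000 nM, most likely reported again only as a limit.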

Compound 4, half-maximal inhibitory concentration: > 40000 nM
Compound 4: a limit, no number; the forecaster's own chance of this, stated with the estimate: 80%; the middle value lies on the limit itself.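

In this assay compound 4 gives > 40000 nM, which is a limit and not a number, so the steps from compound 2 and compound 3 to compound 4 cannot be read. The compounds shown leave open whether any group on the aromatic nitrogen changes inhibition, as all values share one limit: the limit of > 40000 nM in this assay, at which 4 of the 4 values shown sit.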